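Compound 4: 3-chlorophenyl replacing 4-methoxyphenyl

A few compounds are considered here, and "the series" means these few. Any claim that something is new, unique, unknown or untested is made for them only; others in the source may bear on it.

In a functional assay on A549 cells (Homo sapiens) for antiproliferative activity, read by MTT assay, with a stated time of 48 h (on this read-out higher numbers stand for weaker inhibition and lower numbers for stronger inhibition), compound 3 `CCn1cc(-c2ccc(OC)cc2)c(=O)c2cc(F)c(N3CCNCC3)cc21` (at 11600 nM) sits level with compound 2 `CCn1cc(-c2ccccc2)c(=O)c2cc(F)c(N3CCNCC3)cc21` (at 10800 nM) and well above compound 1 `CCn1cc(-c2nc3ccc([N+](=O)[O-])cc3o2)c(=O)c2cc(F)c(N3CCNC(C)C3)c(F)c21` (at 1470 nM). Compound 1 differs from both in more than one place and offers no direct guide. Next is compound 4 `CCn1cc(-c2cccc(Cl)c2)c(=O)c2cc(F)c(N3CCNCC3)cc21` with the change 3-chlorophenyl in place of 4-methoxyphenyl on an aromatic carbon. Among the measured compounds shown here, the only measured step at this place is a 1.1-fold higher number from compound 2 to compound 3 (0.03 log units; within the scatter) (within the scatter). For the measured compounds named here, no chlorine-bearing analogue has been measured, so no shift beyond the scatter is expected in this assay and the direction stays open. The expected change is a 1.2-fold lower number from compound 3 to compound 4 (0.09 log units; within the scatter) (an estimate). For compound 4 the estimated value is 9500 nM (range 4500 nM to 20000 nM).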

Compound 4, half-maximal inhibitory concentration: 780 nM
Compound 4: the middle estimate sits 12-fold (1.09 log units) above what was measured, outside the stated range (below it).
By their numbers in this assay, from the lowest: compounds 4 and 1 (each within the scatter of the next); then compounds 2 and 3 (each within the scatter of the next).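

In this assay the phenyl group on this aromatic carbon turns out to be far from silent: chloro in place of hydrogen gives a 14-fold lower number from compound 2 to compound 4 (1.14 log units; beyond the scatter), and 3-chlorophenyl in place of 4-methoxyphenyl gives a 15-fold lower number from compound 3 to compound 4 (1.17 log units; beyond the scatter). The flat methoxy step, a 1.1-fold higher number from compound 2 to compound 3 (0.03 log units; within the scatter), therefore does not hold for every substituent on this phenyl ring. No measurement at hand accounts for the gain.

As far as these compounds go, the step from compound 3 changes both the group and its ring position, so the contribution of each stays open. Whether 4-chlorophenyl, 3-methoxyphenyl or 3-bromophenyl would match compound 4 remains to be seen.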